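Isopropoxy Added to a Dichloropyridyl Urea: Cytotoxicity Outlook

The source may hold more compounds than are shown below. What is called first, only, known or untested is meant among the compounds shown, and "the series" means these compounds.

Two ureas built on a shared core have been examined for their effect on non-transformed colon cells. Compound 1 `Cc1cc(NC(=O)Nc2cc(Cl)nc(Cl)c2)cc(C)n1` and compound 2 `O=C(Nc1ccnc(Cl)c1)Nc1cc(Cl)nc(Cl)c1` were both run in an ADME assay on NCM460 cells (Homo sapiens) for cytotoxicity, read by MTT assay, with a stated time of 72 h, in the presence of a further agent that is not named here; on this read-out higher numbers stand for an effect only at larger amounts of compound and lower numbers for an effect already at smaller amounts. In this assay compound 1 gives 576000 nM, and in this assay compound 2 gives 55300 nM. Compound 2 thus stands at the lowest of the two numbers, with compound 1 a clear step above it, beyond the scatter.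

Compound 3 `CC(C)Oc1cc(NC(=O)Nc2cc(Cl)nc(Cl)c2)cc(Cl)n1` has not yet been measured in this assay. It differs from compound 2 in one place: isopropoxy in place of hydrogen on an aromatic carbon, next to the ring nitrogen and meta to a chloro group. For the measured compounds named here, no step between measured compounds runs through such a change, so nothing measured here shows how an isopropoxy group at that place moves the read-out. The account therefore expects only a small step from compound 2 to compound 3, within or barely beyond the scatter, with no direction preferred: a 1.2-fold lower number from compound 2 to compound 3 (0.09 log units; within the scatter). Compound 3 is estimated to give 45000 nM in this assay, within a range from 12000 nM to 160000 nM.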

Compound 3, half-maximal effective concentration: 21100 nM
Estimate against measurement, compound 3: 2.1-fold (0.33 log units) above; low and high end bracket the measured number.
By their numbers in this assay, from the lowest: compound 3; then compound 2; then compound 1.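

Isopropoxy in place of hydrogen on an aromatic carbon, next to the ring nitrogen and meta to a chloro group, now has a measured outcome: in this assay the change gives a 2.6-fold lower number from compound 2 to compound 3 (0.42 log units; beyond the scatter). The place therefore accepts this group, and the effect on these non-transformed colon cells appears at smaller rather than larger amounts of compound, although the size of the step is modest. Nothing available here bears on what lies behind this step.

A single group at a single place gives one step and no trend, so the compounds shown leave open whether methoxy, an amine or a longer chain at the same aromatic carbon would move the number in the same direction or by a similar amount. They also leave open whether isopropoxy would produce a comparable step on the core of compound 1, or whether the step seen here belongs only to the chloro-bearing ring of compound 2.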